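A few compounds are considered here, and "the series" means these few. Any claim that something is new, unique, unknown or untested is made for them only; others in the source may bear on it.

Of the compounds shown here, three of a shared core have been measured so far. For the measured compounds named here, compound 1 `COC(=O)c1cccc(-c2cnc(C(=O)CCCCCCc3ccccc3)o2)c1` gives 12 nM in an assay (Rattus norvegicus) for inhibition of Fatty-acid amide hydrolase 1 (Homo sapiens) (on this read-out higher numbers stand for weaker inhibition and lower numbers for stronger inhibition), and compound 2 `O=C(CCCCCCc1ccccc1)c1ncc(-c2cccc(C(=O)C(F)(F)F)c2)o1` gives 16 nM; the one measured step between them, a 1.3-fold higher number from compound 1 to compound 2 (0.12 log units; within the scatter), is the replacement of one carbonyl substituent by another. Compound 3 `COc1ccc(-c2cnc(C(=O)CCCCCCc3ccccc3)o2)cc1` gives 100 nM, the highest of the three numbers and beyond the scatter from both others, so it is the weakest inhibitor of the set.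

Compound 4 `CC(=O)c1cnc(C(=O)CCCCCCc2ccccc2)o1` is not yet measured. It differs from compound 3 in one place: acetyl in place of 4-methoxyphenyl on an aromatic carbon. Going by the values given here, no measured step concerns this change; the step from compound 1 to compound 2 touches only the group on the carbonyl carbon of the aryl substituent and leaves the aryl group itself in place, so it bears on compound 4 only indirectly. Because compound 3 already gives 100 nM, and a much smaller group now replaces the aryl group, a further loss of inhibition is expected, of about a 3.0-fold higher number from compound 3 to compound 4 (0.48 log units; beyond the scatter). Compound 4 is therefore estimated at 300 nM, in the range 60 nM to 1500 nM.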

Compound 4, inhibition constant: 2 nM
For compound 4 the middle estimate is 150-fold (2.18 log units) above the measured one; measured number below the stated range.
By their numbers in this assay, from the lowest: compound 4; then compounds 1 and 2 (each within the scatter of the next); then compound 3.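

Replacing the 4-methoxyphenyl group with acetyl on the aromatic carbon next to the ring oxygen gives a 50-fold lower number from compound 3 to compound 4 (1.70 log units; beyond the scatter) in this assay, the largest step seen so far in this series. Compounds 1, 2 and 3 all carry a six-membered aromatic ring at this position, so they could not show that a small group with no ring is compatible with strong inhibition here. Nothing at hand explains the size of this step.

The compounds shown leave open whether the carbonyl of the acetyl group matters or whether removing the ring alone accounts for the step. They also do not tell how a nitrile, a methyl ester or a plain ethyl group on this same carbon would compare with acetyl.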